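From 3,4-dichlorobenzyl to 4-methoxybenzyl on a shared core

The source may report more compounds than this note shows. Statements on the series, on what has been measured and on what is new or still open speak of the compounds shown alone.

Compound 1 `Nc1cc(N)c2nc(-c3ccccc3)c(Oc3ccc(Cl)c(Cl)c3)nc2c1`: < 100000 nM
Compound 2 `Nc1cc(N)c2nc(-c3ccccc3)c(NCc3ccc(Cl)c(Cl)c3)nc2c1`: 17400 nM
Compound 3 `CCOC(=O)[C@H](CCC(=O)O)NC(=O)c1ccc(Oc2nc3cc(N)cc(N)c3nc2-c2ccccc2)cc1`: < 100000 nM

Among the compounds with values here, in a functional assay on CCRF-CEM cells (Homo sapiens) for inhibition, read by sulforhodamine B assay, with a stated time of 48 h (on this read-out higher numbers stand for lower toxicity in this test and lower numbers for higher toxicity in this test), compound 2 gives 17400 nM, the only full number among the three values shown. For compound 1 the reported < 100000 nM is a limit of the assay. For compound 3 the reported < 100000 nM is likewise a limit. Compound 2 therefore stands alone as the single quantified point, set against (the limit of < 100000 nM in this assay, at which 2 of the 3 values shown sit).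

Compound 4 `COc1ccc(CNc2nc3cc(N)cc(N)c3nc2-c2ccccc2)cc1` differs from compound 2 by 4-methoxyphenyl in place of 3,4-dichlorophenyl on a saturated chain carbon bound to a nitrogen on an aromatic ring. No measured pair isolates this change, so its size is not anchored by any shown step. The expected step from compound 2 to compound 4 is a 1.7-fold higher number from compound 2 to compound 4 (0.24 log units; within the scatter), a modest shift toward lower toxicity that may not exceed the scatter. Compound 4 is estimated at 30000 nM, with a range from 10000 nM to 100000 nM.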

Compound 4, concentration lethal to 50% of the cells: < 100000 nM
Compound 4: no number, only a limit; the forecaster's own chance of this, stated with the estimate: 25%; the middle value is on the limit's open side.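

In this assay, within the data shown here, compound 4 gives < 100000 nM, which is a limit of the assay, so no step from compound 2 to compound 4 can be read. The compounds shown leave open what size of shift, if any, 3,4-dichlorobenzyl to 4-methoxybenzyl brings.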